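Series notes: compound 3 to compound 4

The compounds below may be only part of what the source reports. "The series", "measured", "known", "first", "only" and "open" are said of these compounds alone.

In an in vitro functional assay on cells for agonist activity at Bombesin receptor subtype-3 (Homo sapiens), read by luminescence and calcium flux (on this read-out lower numbers stand for an effect already at smaller amounts and higher numbers for an effect only at larger amounts of compound), compound 3 `O=C(O)c1ccccc1-c1ccc(CCc2ncc(Cc3ccccc3Cl)[nH]2)cc1` gives 292 nM, the lowest of the three numbers in hand. Compound 1 `O=C(O)c1ccccc1-c1ccc(CCc2ncc(CC3CCC3)[nH]2)cc1` gives 588 nM, and a 2.0-fold lower number from compound 1 to compound 3 (0.30 log units; within the scatter). Compound 2 `N#Cc1ccccc1Cc1cnc(CCc2ccc(-c3ccccc3C(=O)O)cc2)[nH]1` gives 5480 nM; a 19-fold lower number from compound 2 to compound 3 (1.27 log units; beyond the scatter), and a 9.3-fold higher number from compound 1 to compound 2 (0.97 log units; beyond the scatter).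

Compound 4 `CC(C)CCc1cnc(CCc2ccc(-c3ccccc3C(=O)O)cc2)[nH]1` is not yet measured. It differs from compound 3 as isobutyl in place of 2-chlorophenyl on a saturated chain carbon bound to an aromatic carbon. For the measured compounds named here, the step that bears on it most directly is a 2.0-fold lower number from compound 1 to compound 3 (0.30 log units; within the scatter), which exchanged cyclobutyl for the same 2-chlorophenyl and stayed within the scatter; isobutyl, like cyclobutyl, brings no ring, so the reverse exchange here is expected to move the number no further than that step did. The two large steps turn on cyano in compound 2 and do not apply, since neither compound 3 nor compound 4 carries a nitrile. A small rise toward the neighbourhood of compound 1 is therefore expected, with the step of a 2.4-fold higher number from compound 3 to compound 4 (0.38 log units; beyond the scatter) estimated to sit at or just beyond the scatter. For compound 4 the estimate is 700 nM, with a range from 250 nM to 2000 nM.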

Compound 4, half-maximal effective concentration: 119 nM
Compound 4: middle estimate off by 5.9-fold (0.77 log units), on the high side; the measured number lies below the stated range.
By their numbers in this assay, from the lowest: compound 4; then compounds 3 and 1 (each within the scatter of the next); then compound 2.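

In this assay a ring is not needed at this place, on a saturated chain carbon bound to an aromatic carbon: isobutyl, which has no ring, gives a 2.5-fold lower number from compound 3 to compound 4 (0.39 log units; beyond the scatter) against 2-chlorophenyl and a 4.9-fold lower number from compound 1 to compound 4 (0.69 log units; beyond the scatter) against cyclobutyl in the same place. Against 2-cyanophenyl it gives a 46-fold lower number from compound 2 to compound 4 (1.66 log units; beyond the scatter) as the widest step in the series so far, and compound 4 now stands apart from all three earlier compounds, with every step to them beyond the scatter. No measurement in hand accounts for the advantage of isobutyl over the ring-bearing groups.

For the compounds shown here, only one group without a ring appears here, so it remains open whether the branch matters or the open chain alone. A straight butyl chain, a longer chain or an amine in this place would bear on that question.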